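A few compounds are considered here, and "the series" means these few. Any claim that something is new, unique, unknown or untested is made for them only; others in the source may bear on it.

Measured in a toxicity assay on L02 cells (Homo sapiens) for cytotoxicity, read by MTT assay, with a stated time of 72 h; a higher number here means a weaker inhibitor, a lower number a stronger inhibitor:
- Compound 1 `O=C1c2c[n+]([O-])c3ccccc3c2C(=O)c2c1c1ccccc1n2Cc1cn(C[C@H](O)CO)nn1` gives 1130 nM
- Compound 2 `CN1CCN(CCCCn2c3c(c4ccccc42)C(=O)c2c[n+]([O-])c4ccccc4c2C3=O)CC1` gives 80 nM
- Compound 3 `CN1CCN(CCCn2c3c(c4ccccc42)C(=O)c2c[n+]([O-])c4ccccc4c2C3=O)CC1` gives 230 nM

Compound 3 stands in the middle of these numbers, higher than compound 2 and lower than compound 1. Compound 4 `CN1CCN(CCCCCCn2c3c(c4ccccc42)C(=O)c2c[n+]([O-])c4ccccc4c2C3=O)CC1` is not yet measured. Its difference from compound 3 is 3-(4-methylpiperazin-1-yl)propyl in place of 4-methylpiperazin-1-yl on a saturated chain carbon, three bonds along the chain from an aromatic nitrogen. In words, 3-(4-methylpiperazin-1-yl)propyl sits in place of 4-methylpiperazin-1-yl on a saturated chain carbon, three bonds along the chain from an aromatic nitrogen, so the chain grows longer.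

Going by the values given here, the one comparable measured change is modest: a 2.9-fold higher number from compound 2 to compound 3 (0.46 log units; beyond the scatter). Read in reverse, the longer chain has the lower number. The steps from compound 1 are larger but exchange a different side chain, so they bear less on this change. A single step is thin evidence, but a modest further fall in this assay is expected. The estimated change is a 3.8-fold lower number from compound 3 to compound 4 (0.58 log units; beyond the scatter). Compound 4 is expected at 60 nM, with an estimated range of 20 nM to 180 nM.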

Compound 4, half-maximal inhibitory concentration: 3800 nM
For compound 4 the middle estimate is 63-fold (1.80 log units) below the measured one; the whole stated range lies below it.
By their numbers in this assay, from the lowest: compound 2; then compound 3; then compound 1; then compound 4.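

Growing the chain at this position does not keep lowering the number in this assay: there is a 17-fold higher number from compound 3 to compound 4 (1.22 log units; beyond the scatter), and a 48-fold higher number from compound 2 to compound 4 (1.68 log units; beyond the scatter), so among these compounds the lowest number sits at the middle chain length, not the longest. The longest chain even ends above the triazole side chain, with a 3.4-fold higher number from compound 1 to compound 4 (0.53 log units; beyond the scatter). No measurement at hand explains this reversal. Still open, going by these compounds, is where the number turns upward between compound 2 and compound 4. Also open, on these data alone, are what a longer chain would do and whether a morpholine ring at the chain end would follow the same course.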